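Isopropoxy at the Five-Membered Ring: Step to Compound 3

A few compounds are considered here, and "the series" means these few. Any claim that something is new, unique, unknown or untested is made for them only; others in the source may bear on it.

Compound 2 `O=S(=O)(Nc1ccc(F)c(C#Cc2cnc3[nH]ncc3c2)c1F)c1cccc(Cl)c1` gives 5.1 nM in an assay on cells for inhibition of mitogen-activated protein kinase kinase kinase 20 (Homo sapiens), read by ADP-Glo, with a stated time of 30 min (on this read-out higher numbers stand for weaker inhibition and lower numbers for stronger inhibition), the higher of the two numbers in hand; compound 1 `COc1n[nH]c2ncc(C#Cc3c(F)ccc(NS(=O)(=O)c4cccc(Cl)c4)c3F)cc12` gives 4.2 nM, and the two lie within the scatter. Compound 3 `CC(C)Oc1n[nH]c2ncc(C#Cc3c(F)ccc(NS(=O)(=O)c4cccc(Cl)c4)c3F)cc12` differs from compound 2 by isopropoxy in place of hydrogen on an aromatic carbon. Among the measured compounds shown here, the one step that bears on this place, a 1.2-fold higher number from compound 1 to compound 2 (0.08 log units; within the scatter), was within the scatter, so a change at this carbon has so far moved nothing beyond it. For compound 3 a step of a 1.1-fold lower number from compound 2 to compound 3 (0.05 log units; within the scatter) is therefore expected, no more than the scatter. Compound 3 is estimated at 4.5 nM, within 1.5 nM to 13 nM.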

Compound 3, half-maximal inhibitory concentration: 42.7 nM
Estimate against measurement, compound 3: 9.5-fold (0.98 log units) below; the whole stated range lies below it.
By their numbers in this assay, from the lowest: compounds 1 and 2 (each within the scatter of the next); then compound 3.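

At this aromatic carbon of the five-membered ring, this assay turns out not to be indifferent to the group: hydrogen and methoxy stand within the scatter of each other, yet isopropoxy gives an 8.4-fold higher number from compound 2 to compound 3 (0.92 log units; beyond the scatter) and a clear loss follows. Isopropyl in place of methyl on the oxygen gives a 10-fold higher number from compound 1 to compound 3 (1.01 log units; beyond the scatter), so an oxygen at this carbon is not enough to account for the rise, as compound 1 carries one too. Nothing at hand explains the loss.

The compounds shown leave open how the number moves with ethoxy at this carbon. They also leave open whether an amine there would follow methoxy or isopropoxy.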